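This account rests on a few compounds, and the source may have more. Where it says the series, first, only, none or still open, it means among the compounds named here.

Working notes on the series. Going by the values given here, in a functional assay on BGC-823 cells (Homo sapiens) for antiproliferative activity, read by MTT assay, tested at 5 uM (on this read-out lower numbers stand for a weaker effect and higher numbers for a stronger effect at the one concentration tested), compound 1 `COc1cc(C(=O)N/N=C/c2ccc(F)c(F)c2)cc(OC)c1OC` gives 51.9% and compound 3 `COc1cc(C(=O)N/N=C/c2cccc(F)c2)cc(OC)c1OC` gives 44.8%; the step of a number 7.1 percentage points lower from compound 1 to compound 3 (within the scatter) is the only one-place change measured so far. Compound 2 `COc1cc(C2=NN(C(C)=O)C(c3ccc(F)cc3)O2)cc(OC)c1OC` gives 13.3%, the lowest of the three numbers, with the gap to compound 3 and the larger gap to compound 1 both beyond the scatter. Compound 4 `COc1ccc(OC)c(C2OC(c3cc(OC)c(OC)c(OC)c3)=NN2C(C)=O)c1` differs from compound 2 by 2,5-dimethoxyphenyl in place of 4-fluorophenyl on a saturated ring carbon. Among the compounds with values here, no measured step touches an aryl group on this saturated ring carbon, and the single step known is within the scatter on a different core, so no step beyond the scatter is expected in this assay. Compound 4 is expected near 18%, in a range from 5% to 40%, an estimated step of a number 4.7 percentage points higher from compound 2 to compound 4 (within the scatter).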

Compound 4, a percentage reported as inhibition, at one concentration (the size of the read-out at that concentration, not a potency): 18.2%
For compound 4 the middle estimate is 0.2 percentage points below the measured one; measured number inside the range.
By their numbers in this assay, from the lowest: compounds 2 and 4 (each within the scatter of the next); then compounds 3 and 1 (each within the scatter of the next).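

In this assay, going by these compounds alone, this is the first change read at the saturated ring carbon, and it gives a number 4.9 percentage points higher from compound 2 to compound 4 (within the scatter). Replacing 4-fluorophenyl with 2,5-dimethoxyphenyl, which adds heavy atoms and two hydrogen-bond acceptors, therefore moves the read-out no further than the scatter at this position. No evidence bears on why this exchange has so little effect. The compounds shown leave open whether a non-aromatic group on this carbon, such as a methyl or an aminomethyl group, would behave in the same way. They also leave open what a propionyl group would do in place of the acetyl group on the neighbouring ring atom.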